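The source may report more compounds than this note shows. Statements on the series, on what has been measured and on what is new or still open speak of the compounds shown alone.

Of the compounds shown here, three have been measured in an ADME assay on L1210/0 cells (Mus musculus) for cytotoxicity, with a stated time of 48 h; on this read-out lower numbers stand for stronger inhibition and higher numbers for weaker inhibition. Compound 1 `O=C1O/C(=C\Cn2ccc(=O)[nH]c2=O)C(OCc2ccccc2)=C1OCc1ccccc1` gives 12900 nM, compound 3 `CC(=O)OC(C)Cn1cnc2c(Cl)nc(I)nc21` gives 13000 nM, and compound 2 `O=c1[nH]c(=O)n([C@H]2C[C@H](O)[C@@H](CO)O2)cc1[N+](=O)[O-]` gives 130 nM. Compound 2 therefore has the lowest number of the three, and its gaps to compound 1 and compound 3 both lie well beyond the scatter of repeated measurements, so it stands as the strongest inhibitor among them.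

Compound 4 `CC#Cc1cn([C@H]2C[C@H](O)[C@@H](CO)O2)c(=O)[nH]c1=O` has not yet been measured in this assay. It differs from compound 2 in a single place: prop-1-yn-1-yl in place of nitro on an aromatic carbon. Nothing in the measured set shows what such an exchange does to the read-out, so the expectation rests only on the numbers given. Because compound 2 gives 130 nM, and a nitro group is replaced here by a group with no hydrogen-bond acceptors, a step toward a higher number, beyond the scatter, is expected: the step from compound 2 to compound 4 is estimated as a 62-fold higher number from compound 2 to compound 4 (1.79 log units; beyond the scatter). For compound 4 the expected value in this assay is 8000 nM, within a range from 800 nM to 80000 nM.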

Compound 4, half-maximal inhibitory concentration: > 200000 nM
Compound 4: a limit, no number; the forecaster's own chance of this, stated with the estimate: 10%; at least 25-fold (1.39 log units) between middle value and limit.
By their numbers in this assay, from the lowest: compound 2; then compounds 1 and 3 (each within the scatter of the next). At a limit, above all of these: compound 4.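

In this assay, going by these compounds alone, the exchange of nitro for prop-1-yn-1-yl on this aromatic carbon gives an at least 1500-fold higher number from compound 2 to compound 4 (3.18 log units; beyond the scatter), the first step in the set between compounds that differ in one place. Compound 4 gives only a limit of the assay, > 200000 nM, not a number, so the step has no fixed size: the limit of > 200000 nM in this assay, at which 1 of the 4 values shown sits. Even so, this carbon is clearly sensitive to what it carries, as one exchange with the rest of the molecule unchanged moves the read-out from the lowest number in the set to the limit.

This single pair cannot separate the loss of nitro, with its hydrogen-bond acceptors, from the arrival of the triple bond. Going by these compounds, how an amine, a chlorine atom or a plain hydrogen on this carbon would read out also remains open.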